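A Methoxy for a Chloro Where Nothing Yet Binds

A few compounds are considered here, and "the series" means these few. Any claim that something is new, unique, unknown or untested is made for them only; others in the source may bear on it.

Three compounds share one core and were tested in an in vitro assay on HEK-tsA201 cells for antagonist activity at Neuronal acetylcholine receptor; alpha3/beta4 (Homo sapiens), read by fluorescence and calcium flux; on this read-out lower numbers stand for stronger inhibition and higher numbers for weaker inhibition. Compound 1 `CCCOc1ccc(C(=O)Nc2cccc(Cl)n2)cc1` gives > 100000 nM in this assay, which is a limit of the assay rather than a number. Compound 2 `CCCOc1ccc(C(=O)Nc2cccc(Nc3ccccc3)n2)cc1` gives > 100000 nM, again a limit. Compound 3 `CCCOc1ccc(C(=O)Nc2cccc(Nc3ccc(Cl)cc3)n2)cc1` stands at > 100000 nM, also a limit. All three therefore sit at the limit of > 100000 nM in this assay, at which 3 of the 3 values shown sit, and none of the steps between them can be read: the step that the two limits leave unreadable from compound 1 to compound 2, the step that the two limits leave unreadable from compound 1 to compound 3 and the step that the two limits leave unreadable from compound 2 to compound 3 each run from one limit to another. Compound 4 `CCCOc1ccc(C(=O)Nc2cccc(Nc3ccc(OC)cc3)n2)cc1` differs from compound 3 in a single place: methoxy in place of chloro on an aromatic carbon. Within the data shown here, no measured step shows what this change does here; every neighbour of compound 4 has remained unmeasurable. Accordingly the step that the limit leaves unreadable from compound 3 to compound 4 is expected to be one that this assay cannot resolve. Compound 4 is estimated at 150000 nM, between 20000 nM and 1000000 nM, and most probably will be reported only as a limit.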

Compound 4, half-maximal inhibitory concentration: > 100000 nM
Compound 4 was reported as a limit; the forecaster's own chance of this, stated with the estimate: 85%; the middle value is on the limit's open side.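

No new step can be read, since compound 4 joins compound 1, compound 2 and compound 3 as a limit of the assay rather than a number: the limit of > 100000 nM in this assay, at which 4 of the 4 values shown sit.

The compounds shown leave open whether any change on the shared core gives measurable inhibition, and what methoxy in place of chloro actually does.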